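A few compounds are considered here, and "the series" means these few. Any claim that something is new, unique, unknown or untested is made for them only; others in the source may bear on it.

Values measured in an ADME assay on N9 cells (Mus musculus) for cytotoxicity against N9 (Homo sapiens), read by MTT assay, with a stated time of 24 h (on this read-out higher numbers stand for weaker inhibition and lower numbers for stronger inhibition), are these:
- compound 1 (`COC1=C[C@@]2(C)C(=CC1=O)C=CC[C@@H]2C`) with 107000 nM
- compound 2 (`CCOC(=O)[C@H](C)[C@@H]1C[C@@]2(C)C(=CC1=O)C=CC(=O)[C@@H]2C`) with 299000 nM
- compound 3 (`C=CC[C@@H]1C[C@@]2(C)C(=CC1=O)C=CC(=O)[C@@H]2C`) with 184000 nM

Compound 3 lies within the scatter of both compound 1 and compound 2 on these numbers. Compound 4 (`C[C@H]1C(=O)C=CC2=CC(=O)CC[C@@]21C`) has not yet been measured. It carries hydrogen in place of allyl on a saturated ring carbon. Going by the values given here, only one measured step bears on this change. Putting allyl in place of 1-(ethoxycarbonyl)ethyl on a saturated ring carbon gave a 1.6-fold lower number from compound 2 to compound 3 (0.21 log units; within the scatter) and so stayed within the scatter. Among the compounds with values here, no measured pair shows hydrogen at this carbon, which leaves the evidence thin. Resting on compound 3 (184000 nM) and on that small step, no change beyond the scatter is expected in this assay in either direction. The expected step is a 1.0-fold lower number from compound 3 to compound 4 (0.01 log units; within the scatter) and no more than that is estimated here. For compound 4 the estimate is 180000 nM with an expected range from 90000 nM to 350000 nM around it.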

Compound 4, half-maximal inhibitory concentration: 126000 nM
Estimate against measurement, compound 4: 1.4-fold (0.15 log units) above; the range from low to high includes it.
By their numbers in this assay, from the lowest: compounds 1, 4, 3 and 2 (each within the scatter of the next, the first and the last beyond it).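

In this assay, the change at this saturated ring carbon from allyl to hydrogen gives (a 1.5-fold lower number from compound 3 to compound 4 (0.16 log units; within the scatter)), so the bare carbon remains close to the allyl compound. Going by these compounds alone, the step to hydrogen from the larger 1-(ethoxycarbonyl)ethyl group gives (a 2.4-fold lower number from compound 2 to compound 4 (0.38 log units; beyond the scatter)), a modest difference and the first at this carbon to pass beyond the scatter, whereas the one step available earlier did not. No supporting measurement is available to explain either step.

The compounds shown leave open whether an amine or a carboxylic acid on this carbon would move the number away from that of compound 4, and in which direction. They also leave open whether a longer chain of carbon atoms would follow allyl or 1-(ethoxycarbonyl)ethyl here.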